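This account rests on a few compounds, and the source may have more. Where it says the series, first, only, none or still open, it means among the compounds named here.

Measured so far in a functional assay on MCF7 cells (Homo sapiens) for antiproliferative activity, read by MTT assay, with a stated time of 72 h; a lower number here means a stronger inhibitor, a higher number a weaker inhibitor:
- Compound 1 `COc1cc(-n2cnc3ccc(-c4ccc(C)cc4F)cc32)cc(OC)c1OC` gives 56 nM
- Compound 2 `COc1cc(-n2cnc3ccc(-c4cccc(F)c4)cc32)cc(OC)c1OC` gives 2350 nM

Of these two, compound 2 has the higher number, so it is the weaker inhibitor. Compound 3 `COc1cc(-n2cnc3ccc(-c4ccc(Cl)cc4)cc32)cc(OC)c1OC` keeps the shared core and changes one group (4-chlorophenyl in place of 3-fluorophenyl on an aromatic carbon), with 4-chlorophenyl in place of 3-fluorophenyl on an aromatic carbon. Among the compounds with values here, only one measured step involves this same carbon: a 42-fold higher number from compound 1 to compound 2 (1.62 log units; beyond the scatter), a large change beyond the scatter. A single step cannot show which feature of the group matters. Compound 1, at 56 nM, carries a group with a substituent numbered 4 in its name, as compound 3 does, so a partial return towards compound 1 is expected in this assay. The expected move is a 4.7-fold lower number from compound 2 to compound 3 (0.67 log units; beyond the scatter), a moderate step to a lower number. For compound 3 the estimated value is 500 nM, with an expected range from 100 nM to 2500 nM.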

Compound 3, half-maximal inhibitory concentration: 1320 nM
For compound 3 the middle estimate is 2.6-fold (0.42 log units) below the measured one; low and high end bracket the measured number.
By their numbers in this assay, from the lowest: compound 1; then compounds 3 and 2 (each within the scatter of the next).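

In this assay, placing 4-chlorophenyl on this aromatic carbon instead of 3-fluorophenyl gives a 1.8-fold lower number from compound 2 to compound 3 (0.25 log units; within the scatter), so this change does not separate the two groups. A substituent numbered 4 is therefore not enough on its own to bring the number close to that of compound 1: the step here is a 24-fold higher number from compound 1 to compound 3 (1.37 log units; beyond the scatter), and that large gap remains for both groups with a single halogen on the ring. No measured evidence is available to explain these numbers.

The compounds shown leave open whether the low number of compound 1 depends on the fluorine, the methyl or both together in 2-fluoro-4-methylphenyl. They also leave open how a phenyl group carrying an amine or a carboxylic acid at this position would read in this assay.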